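Arylsulfonamide diamines: tert-butyl for trifluoromethyl at the sulfonyl ring

A few compounds are considered here, and "the series" means these few. Any claim that something is new, unique, unknown or untested is made for them only; others in the source may bear on it.

Values in a functional assay on MIA PaCa-2 cells (Homo sapiens) for inhibition, read by MTT assay, with a stated time of 72 h (a higher number here means a weaker inhibitor of growth, a lower number a stronger inhibitor of growth), so far:
compound 1 `O=S(=O)(NCCCCCCNCc1ccc(Br)cc1)c1ccc(C(F)(F)F)cc1`: 3830 nM
compound 2 `O=S(=O)(NCCCNCc1ccc(Cl)cc1)c1cc(C(F)(F)F)cc(C(F)(F)F)c1`: 2800 nM

Compound 1 stands with the highest of the two numbers in this assay, but its nearest neighbour, compound 2, sits within the scatter of it, so the two cannot be placed in any order. Compound 2 also differs from compound 1 in several places at once, so nothing about a single change can be drawn from that pair.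

Compound 3 `CC(C)(C)c1ccc(S(=O)(=O)NCCCCCCNCc2ccc(Br)cc2)cc1` is the next member to be measured. It differs from compound 1 by tert-butyl in place of trifluoromethyl on an aromatic carbon. Among the compounds with values here, no measured pair shows this change, and the two numbers in hand give no direction for it. The step from compound 1 to compound 3 is therefore expected to stay within the scatter, a 1.1-fold lower number from compound 1 to compound 3 (0.04 log units; within the scatter), with wide uncertainty in either direction. For compound 3 the estimate in this assay is 3500 nM, within a range of 1200 nM to 10000 nM.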

Compound 3, concentration for 50% growth inhibition: 2970 nM
Compound 3: the middle estimate sits 1.2-fold (0.07 log units) above what was measured; measured number inside the range.
By their numbers in this assay, from the lowest: compounds 2, 3 and 1 (each within the scatter of the next).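

In this assay, within the data shown here, tert-butyl in place of trifluoromethyl on an aromatic carbon, para to a large group, gives a 1.3-fold lower number from compound 1 to compound 3 (0.11 log units; within the scatter), the first step that changes only one place. On the core of compound 1, this position therefore tolerates the exchange without a change that can be told from the scatter, and the two compounds cannot be placed in any order. Nothing measured bears on why the step has this size.

On these data alone, whether the same exchange would behave alike on the different chain of compound 2 stays open, as this single step covers only the chain of compound 1. Also open, as far as these compounds go, is whether a nitrile, a carboxylic acid or an amine at this position would move the number beyond the scatter.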